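Hydroxy for Chloro: Expected Effect on Cell Viability

The compounds below may be only part of what the source reports. "The series", "measured", "known", "first", "only" and "open" are said of these compounds alone.

Two hydrazones from one study have been measured so far. Compound 1 `O=C(N/N=C/c1cccc(Cl)c1)c1cnccn1` carries a chloro group, and in an ADME assay on J774 cells (Mus musculus) for cytotoxicity, read by MTT assay, with a stated time of 48 h, tested at 50 ug/mL (a higher number here means a weaker effect of the compound at the concentration tested, a lower number a stronger effect), compound 1 gives 100%. In this assay compound 2 `COc1ccc(/C=N/NC(=O)c2cnccn2)cc1` gives 74%. Compound 1 therefore stands highest of the two numbers, with compound 2 lower by a gap beyond the usual scatter of this measurement. Compound 3 `O=C(N/N=C/c1cccc(O)c1)c1cnccn1` has not yet been measured. It differs from compound 1 by hydroxy in place of chloro on an aromatic carbon, the change sitting on an aromatic carbon of a six-membered aromatic ring of carbon only. Going by the values given here, no measured pair shows this kind of change, so what follows is an expectation only. The expected step of a number 8 percentage points lower from compound 1 to compound 3 (within the scatter) is small and downward, most likely within the scatter, because compound 1 already stands at 100% and leaves little room upward. Compound 3 is estimated at 92%, with a range from 70% to 105%.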

Compound 3, a percentage reported as activity, at one concentration (the size of the read-out at that concentration, not a potency): 100%
Estimate against measurement, compound 3: 8 percentage points below; low and high end bracket the measured number.
By their numbers in this assay, from the lowest: compound 2; then compounds 1 and 3 (each within the scatter of the next).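

Hydroxy in place of chloro on an aromatic carbon, meta to a large group, gives no change at the digits printed from compound 1 to compound 3 (within the scatter) in this assay, the first step read at this position. At the concentration tested, this read-out does not separate the two compounds, although the entering hydroxy brings a hydrogen-bond donor and a hydrogen-bond acceptor that the leaving chloro lacks. The position therefore tolerates this one exchange in this read-out, though that single pair supports no wider rule. No supporting measurement is available to explain this result.

The compounds shown leave open whether an amine or a carboxylic acid on the same aromatic carbon would also read alike in this assay. They also leave open whether hydroxy in place of chloro would give a similar result elsewhere on that ring.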